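The compounds below may be only part of what the source reports. "The series", "measured", "known", "first", "only" and "open" are said of these compounds alone.

Measured in an ADME assay on microsomes from liver (Rattus norvegicus) for metabolic stability, using NADPH, with a stated time of 10 min; on this read-out lower numbers stand for a less stable compound and higher numbers for a more stable compound:
- compound 1 `CN(C[C@H]1Cc2c(cccc2N2CCC(N)CC2)CN1)[C@H]1CCCc2cccnc21`: 38.4%
- compound 2 `CN(C[C@H]1Cc2c(cccc2N2C[C@H]3CCN(C)[C@H]3C2)CN1)[C@H]1CCCc2cccnc21`: 11.2%
- compound 3 `CN(C[C@H]1Cc2c(cccc2N[C@H]2CC[C@H](N)CC2)CN1)[C@H]1CCCc2cccnc21`: 75%

Compound 3 has the highest of the three values, and its steps to both other compounds are beyond the scatter. Compound 4 `CN1C[C@@H]2CN(c3cccc4c3C[C@H](CN(C)[C@H]3CCCc5cccnc53)NC4)C[C@@H]2C1` is not yet measured. It differs from compound 3 on an aromatic carbon of the shared core: a group of 9 heavy atoms (7 carbon, 2 nitrogen; 2 five-membered non-aromatic rings with 1 hetero atom each) in place of a group of 8 heavy atoms (6 carbon, 2 nitrogen; one six-membered non-aromatic ring of carbon only), on an aromatic carbon.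

The closest evidence is a number 63.8 percentage points higher from compound 2 to compound 3 (beyond the scatter), a large step. Among the compounds with values here, compound 2 also carries a group with 2 five-membered non-aromatic rings with 1 hetero atom each, although its group is not the same as the one in compound 4. That step therefore runs the same kind of exchange in the opposite direction. Also relevant are a number 36.6 percentage points higher from compound 1 to compound 3 (beyond the scatter), which is large, and a number 27.2 percentage points lower from compound 1 to compound 2 (beyond the scatter), which is modest.

A large fall in this assay, beyond the scatter, is expected here. The expected change is a number 60 percentage points lower from compound 3 to compound 4 (beyond the scatter). The estimate for compound 4 is 15%, with an expected range of 5% to 35%.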

Compound 4, percent of the compound remaining: 35.3%
Compound 4: the middle estimate sits 20.3 percentage points below what was measured; the measured number lies above the stated range.
By their numbers in this assay, from the lowest: compound 2; then compounds 4 and 1 (each within the scatter of the next); then compound 3.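

In this assay, a second group with two five-membered non-aromatic rings on this aromatic carbon also falls short of (4-aminocyclohexyl)amino (a number 39.7 percentage points lower from compound 3 to compound 4 (beyond the scatter)), so this result no longer rests on a single group of that kind. The two such groups are not interchangeable despite sharing the same printed counts (a number 24.1 percentage points higher from compound 2 to compound 4 (beyond the scatter)), so the arrangement of the two rings carries weight at this position. The new group cannot be told apart from 4-aminopiperidin-1-yl (a number 3.1 percentage points lower from compound 1 to compound 4 (within the scatter)), which is within the scatter.

From the compounds shown here alone, whether the higher value of compound 3 follows the ring of carbon only or the amino link remains open, as does how a morpholine or an open-chain diamine would read on the same aromatic carbon. No measurement at hand accounts for any of these steps.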